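From Methyl to Isobutyl at the Assay Limit

The source may report more compounds than this note shows. Statements on the series, on what has been measured and on what is new or still open speak of the compounds shown alone.

In a functional assay on CCRF-CEM cells (Homo sapiens) for antiproliferative activity, read by MTT assay, with a stated time of 48 h (a higher number here means that more compound is needed for the effect, a lower number that less compound is needed), compound 1 (`COC(=O)c1[nH]c2cc(OC)ccc2c1-c1ccc(Br)cc1`) gives 330 nM as a measured number. Compound 2 (`COC(=O)c1[nH]c2cc(C(F)(F)F)ccc2c1-c1ccc(C(F)(F)F)cc1`) gives > 100000 nM as a limit and not a number. Compound 3 (`COC(=O)c1[nH]c2cc(OC)ccc2c1C`) gives > 100000 nM as a limit too, so compound 3 stands at the limit of > 100000 nM in this assay, at which 2 of the 3 values shown sit, and has no number of its own.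

Compound 4 (`COC(=O)c1[nH]c2cc(OC)ccc2c1CC(C)C`) differs from compound 3 by isopropyl in place of hydrogen on a saturated chain carbon bound to an aromatic carbon and so turns methyl into isobutyl. Going by the values given here, only one measured step bears on this change, and it is large: an at least 300-fold higher number from compound 1 to compound 3 (2.48 log units; beyond the scatter) with methyl in place of 4-bromophenyl on an aromatic carbon. Among the compounds with values here, no measured compound carries a saturated chain longer than methyl in that place, so the size of the new step is poorly constrained. Compound 1 reaches 330 nM with its 4-bromophenyl, whereas isobutyl has no ring, so only a small part of that large step is expected to return. The expected change is an at least 2.0-fold lower number from compound 3 to compound 4 (0.30 log units; that floor lies within the scatter) in the direction of a lower number, and a reading that stays at the limit is quite possible. Compound 4 is estimated at 50000 nM in this assay (expected range 8000 nM to 100000 nM).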

Compound 4, half-maximal effective concentration: 16600 nM
The estimate for compound 4 lay 3.0-fold (0.48 log units) above the measured number; low and high end bracket the measured number.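

Turning methyl into isobutyl moves the reading in this assay off the assay limit, with an at least 6.0-fold lower number from compound 3 to compound 4 (0.77 log units; beyond the scatter), so a group without a ring at this place can still give a measured number. The 4-bromophenyl group stays well ahead of isobutyl, with a 50-fold higher number from compound 1 to compound 4 (1.70 log units; beyond the scatter), and the chain therefore returns only part of an at least 300-fold higher number from compound 1 to compound 3 (2.48 log units; beyond the scatter). Compound 3 itself remains a limit and not a number, so the gain from the chain has only a floor and no upper bound: the limit of > 100000 nM in this assay, at which 2 of the 4 values shown sit.

With methyl and isobutyl as the only saturated groups at this place, the compounds shown give no trend with chain size, and they do not tell whether a longer chain such as n-hexyl or a saturated ring such as cyclohexyl would narrow the remaining gap to compound 1. They also do not separate the part played by the bromine from that of the phenyl ring, since a plain phenyl group is not among them and compound 2 differs from compound 1 in more than one place.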